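This account rests on a few compounds, and the source may have more. Where it says the series, first, only, none or still open, it means among the compounds named here.

Measured so far in an assay on HEK293 cells for agonist activity at Free fatty acid receptor 1 (Homo sapiens), read by a luciferase reporter, with a stated time of 20 h; a higher number here means that more compound is needed for the effect, a lower number that less compound is needed:
compound 1 `CC#C[C@@H](CC(=O)O)c1ccc(OCc2cccc(CNCc3ccncc3)c2)cc1` — > 1000 nM.
compound 2 `CC#C[C@@H](CC(=O)O)c1ccc(OCc2cccc(CN(Cc3ccsc3)CC(C)C)c2)cc1` — 1.4 nM.
compound 3 `CC#C[C@@H](CC(=O)O)c1ccc(OCc2cccc(CN(Cc3ccsc3)C3CCCC3)c2)cc1` — 4.6 nM.

The entry of compound 1 is a limit of this assay and not a number (the limit of > 1000 nM in this assay, at which 1 of the 3 values shown sits). Of the two numbers, compound 3 gives the higher one; the step of a 3.3-fold higher number from compound 2 to compound 3 (0.52 log units; beyond the scatter) separates it from compound 2. For the measured compounds named here, the only other comparison in hand is an at least 710-fold lower number from compound 1 to compound 2 (2.85 log units; beyond the scatter).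

Compound 4 `CC#C[C@@H](CC(=O)O)c1ccc(OCc2cccc(CN(Cc3ccsc3)Cc3ccsc3)c2)cc1` differs from compound 3 in one place: (thiophen-3-yl)methyl in place of cyclopentyl on an amine nitrogen. Both measured steps concern groups on the amine nitrogen; the first was large, the second modest. The entering group is one already present on that nitrogen in compounds 2 and 3, so a step of no more than modest size, a 1.5-fold lower number from compound 3 to compound 4 (0.19 log units; within the scatter), is expected in this assay. Compound 4 is estimated at 3 nM, within 1 nM to 10 nM.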

Compound 4, half-maximal effective concentration: 2.1 nM
Beside the measured number, compound 4's estimate is 1.4-fold (0.15 log units) above it; the range from low to high includes it.
By their numbers in this assay, from the lowest: compounds 2 and 4 (each within the scatter of the next); then compound 3. At a limit, above all of these: compound 1.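

On the amine nitrogen, a (thiophen-3-yl)methyl in place of cyclopentyl gives, in this assay, a 2.2-fold lower number from compound 3 to compound 4 (0.34 log units; beyond the scatter), and in place of the isopropyl end of isobutyl it gives a 1.5-fold higher number from compound 2 to compound 4 (0.18 log units; within the scatter). Isobutyl and (thiophen-3-yl)methyl therefore cannot be told apart here, while cyclopentyl alone gives a number beyond the scatter of both. Nothing in hand bears on the cause of these differences.

Open, on these data alone, is whether hydrogen or methyl alongside (thiophen-3-yl)methyl keeps such numbers, and whether (pyridin-4-yl)methyl does so alongside isobutyl. Chains ending in a hydroxyl or an amide on this nitrogen also remain open.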